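This account rests on a few compounds, and the source may have more. Where it says the series, first, only, none or still open, it means among the compounds named here.

Compound 1, whose structure is `O=C(CCc1cccc2c1B(O)OC2)Nc1cccc(-c2ccccc2)c1`, is measured in a functional assay on MDA-MB-231 cells (Homo sapiens) for antiproliferative activity, read by MTT assay, with a stated time of 72 h (a higher number here means a weaker inhibitor, a lower number a stronger inhibitor), where compound 1 gives 220 nM. Compound 2, with structure `COc1ccc(-c2cccc(NC(=O)CCc3cccc4c3B(O)OC4)c2)cc1`, differs from it by a single change, (methoxy in place of hydrogen on an aromatic carbon); in this assay compound 2 gives 88 nM, and the step of a 2.5-fold lower number from compound 1 to compound 2 (0.40 log units; beyond the scatter) is the only measured step of this change among the compounds shown.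

Compound 3, with structure `COc1cccc(-c2cccc(NC(=O)CCc3ccccc3)c2)c1`, is built on a different core; how its core differs from the core of compound 1 is not broken down here. In this assay compound 3 gives 25000 nM, the highest of the three numbers, and both compound 1 and compound 2 sit far below it.

Compound 4, with structure `COc1cc(OC)cc(-c2cccc(NC(=O)CCc3ccccc3)c2)c1`, has not yet been measured. It differs from compound 3 by methoxy in place of hydrogen on an aromatic carbon. This is the same kind of change as from compound 1 to compound 2, but the place is not the same: in compound 2 the methoxy sits para to a large group, while in compound 4 it sits meta to a large group and meta to a methoxy group. Among the measured compounds shown here, for compound 4 a step of a 1.7-fold lower number from compound 3 to compound 4 (0.22 log units; within the scatter) is expected, resting on the single measured step of a 2.5-fold lower number from compound 1 to compound 2 (0.40 log units; beyond the scatter) and on the different place of the change, which leaves the size uncertain. Compound 4 is therefore estimated to give 15000 nM in this assay, expected to lie between 5000 nM and 50000 nM.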

Compound 4, half-maximal inhibitory concentration: 87000 nM
Compound 4: middle estimate off by 5.8-fold (0.76 log units), on the low side, outside the stated range (above it).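

In this assay, the new step, a 3.5-fold higher number from compound 3 to compound 4 (0.54 log units; beyond the scatter), runs in the opposite direction to the earlier step, a 2.5-fold lower number from compound 1 to compound 2 (0.40 log units; beyond the scatter). Set side by side, the same change does not give the same result on the two cores, so the earlier step could not simply be carried over to this one: the same change on two cores in this assay, a 2.5-fold lower number (0.40 log units; beyond the scatter) from compound 1 to compound 2 and a 3.5-fold higher number (0.54 log units; beyond the scatter) from compound 3 to compound 4, 8.7-fold (0.94 log units) apart, beyond the scatter of two such steps

Among the compounds shown here, this does not show that the core alone sets the outcome, since the two methoxy groups also stand in different places: the new one in compound 4 sits meta to a large group and meta to a methoxy group, unlike the one in compound 2, and with only one step on each core the effects of core and place cannot be separated.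

The compounds shown leave open what a methoxy would do on the core of compound 1 in the place it holds in compound 4, and on the core of compound 3 in the place it holds in compound 2. They also leave open whether a hydroxyl group or a fluorine atom in place of the same hydrogen would follow the methoxy on either core.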